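Pyridin-2-yl for Pyrimidin-2-yl on the Amide-type Nitrogen

The source may report more compounds than this note shows. Statements on the series, on what has been measured and on what is new or still open speak of the compounds shown alone.

Two compounds of the series have numbers in a functional assay on the whole organism with Rattus norvegicus as the target, read by spectrophotometry, with stated times of 14 days and 3 days, at a dose of 10 mg/kg by the oral route; on this read-out lower numbers stand for less inhibition and higher numbers for more inhibition at the one dose given (going by the name of the read-out). Compound 1 `O=C1c2cc(Cl)c(Cl)cc2C(=O)N1c1ncccn1` gives 32% in this assay, the highest of the two numbers. Among the measured compounds shown here, compound 2 `O=C1c2c(Cl)c(Cl)c(Cl)c(Cl)c2C(=O)N1c1ccncc1` gives 3% in this assay, a number sitting under that of compound 1 by a gap beyond the scatter; compound 2 differs from compound 1 in more than one place, so no single step is drawn between them.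

Compound 3 `O=C1c2cc(Cl)c(Cl)cc2C(=O)N1c1ccccn1` is not yet measured. It differs from compound 1 at one place: pyridin-2-yl in place of pyrimidin-2-yl on an amide-type nitrogen in a ring. The change keeps the ring size and the pattern of chlorine on the shared core, and trades one ring nitrogen for a ring carbon, so one hydrogen-bond acceptor is lost.

For the measured compounds named here, no step between measured compounds shows what such a swap does here, and the number for compound 2 rests on a different ring and a different chlorine count. With nothing in the numbers pointing up or down, the expected step is a number 2 percentage points lower from compound 1 to compound 3 (within the scatter), not beyond the scatter. Compound 3 is thus expected to give about 30% in this assay, most likely between 10% and 55%.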

Compound 3, a percentage reported as inhibition, in the whole organism at one dose (the size of the read-out at that dose, not a potency): 3%
Estimate against measurement, compound 3: 27 percentage points above; measured number below the stated range.
By their numbers in this assay, from the lowest: compounds 2 and 3 (each within the scatter of the next); then compound 1.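

In this assay the group on the amide-type nitrogen proves to matter: pyridin-2-yl in place of pyrimidin-2-yl gives a number 29 percentage points lower from compound 1 to compound 3 (beyond the scatter) with the shared core and its chlorine pattern unchanged. The swap keeps 6 heavy atoms and one six-membered aromatic ring, and moves only from 4 carbon and 2 nitrogen to 5 carbon and 1 nitrogen, with 2 hydrogen-bond acceptors becoming 1, so an exchange of one ring atom is enough to separate this pair beyond the scatter, though this remains a single step and not a trend. No measurement at hand accounts for the size of this step.

Open, on these data alone, is whether the number in this assay depends on the second ring nitrogen itself or on the pyrimidin-2-yl ring as a whole, which a phenyl on the same nitrogen or an amine carried on the pyrimidin-2-yl ring would help to separate. Also open, as far as these compounds go, is whether the step holds on a core with a different chlorine pattern, and at doses other than the one given.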